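From Chloro to Benzyloxy in a Cell Assay

The source may hold more compounds than are shown below. What is called first, only, known or untested is meant among the compounds shown, and "the series" means these compounds.

In a functional assay on HepG2 cells (Homo sapiens) for inhibition, read by CCK-8 assay, with a stated time of 70 h (a lower number here means a stronger inhibitor, a higher number a weaker inhibitor), compound 1 `c1ccc(COc2ccc(OCCOCCNC3CCCC3)cc2)cc1` gives 25400 nM and compound 2 `Clc1ccc(COc2ccc(OCCOCCNC3CCCCC3)cc2)cc1` gives 15100 nM as its reading, two numbers within the usual scatter of each other. Compound 2 therefore stands level with compound 1. Compound 3 `c1ccc(COc2ccc(COc3ccc(OCCOCCNC4CCCCC4)cc3)cc2)cc1` carries benzyloxy in place of chloro on an aromatic carbon, para to a large group (benzyloxy in place of chloro on an aromatic carbon). Among the compounds with values here, no measured pair shows this change alone, so any forecast here stays loose. A modest step toward a lower number is expected in this assay (estimated as a 1.7-fold lower number from compound 2 to compound 3 (0.22 log units; within the scatter)). The estimated value for compound 3 is 9000 nM (expected range 3500 nM to 25000 nM).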

Compound 3, half-maximal inhibitory concentration: 18100 nM
Compound 3: middle estimate off by 2.0-fold (0.30 log units), on the low side; measured number inside the range.
By their numbers in this assay, from the lowest: compounds 2, 3 and 1 (each within the scatter of the next).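

Putting benzyloxy in place of chloro on this aromatic carbon, para to a large group, adds a six-membered aromatic ring, yet this assay shows only a 1.2-fold higher number from compound 2 to compound 3 (0.08 log units; within the scatter). The position therefore takes a group of 8 heavy atoms with no reading that can be told apart from chloro. Nothing available explains this.

As far as these compounds go, whether a carboxylic acid or an amine at the same position would give a different reading stays open. So does whether a longer chain carrying the same ring would match benzyloxy.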